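The source may report more compounds than this note shows. Statements on the series, on what has been measured and on what is new or still open speak of the compounds shown alone.

Compound 3 `O=C(Cn1cc(-c2cccs2)nn1)Nc1nc2ccccc2s1` gives 21400 nM in a functional assay on BMDM cells (Mus musculus, strain C57BL/6) for inhibition, with a stated time of 2 days (on this read-out lower numbers stand for stronger inhibition and higher numbers for weaker inhibition), the highest number among the three measured compounds. Compound 1 `O=C(Cn1cc(-c2ccc([N+](=O)[O-])cc2)nn1)Nc1nc2ccccc2s1` gives 3280 nM in this assay, and compound 2 `COc1ccc(-c2cn(CC(=O)Nc3nc4ccccc4s3)nn2)cc1` gives 1330 nM. Compound 4 `O=C(Cn1cc(-c2ccc(Cl)cc2)nn1)Nc1nc2ccccc2s1` differs from compound 3 in one place: 4-chlorophenyl in place of thiophen-2-yl on an aromatic carbon. Within the data shown here, two measured steps bear on this change: a 6.5-fold higher number from compound 1 to compound 3 (0.81 log units; beyond the scatter) and a 16-fold higher number from compound 2 to compound 3 (1.21 log units; beyond the scatter). Read in reverse, both show that a six-membered aromatic ring of carbon only in place of thiophen-2-yl lowers the number markedly. A step of comparable size in the same direction is therefore expected for compound 4, which is estimated at 2200 nM with a range of 700 nM to 7000 nM. The expected step is a 9.7-fold lower number from compound 3 to compound 4 (0.99 log units; beyond the scatter).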

Compound 4, half-maximal inhibitory concentration: 130 nM
Beside the measured number, compound 4's estimate is 17-fold (1.23 log units) above it, and the stated range ends above it.
By their numbers in this assay, from the lowest: compound 4; then compound 2; then compound 1; then compound 3.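

In this assay, 4-chlorophenyl in place of thiophen-2-yl gives a 160-fold lower number from compound 3 to compound 4 (2.22 log units; beyond the scatter), so having a six-membered aromatic ring of carbon only is not the whole story: the group on that ring also counts. Chloro in place of methoxy gives a 10-fold lower number from compound 2 to compound 4 (1.01 log units; beyond the scatter), and chloro in place of nitro gives a 25-fold lower number from compound 1 to compound 4 (1.40 log units; beyond the scatter), leaving compound 4 with the lowest number of the four. Nothing measured here gives a reason for these steps.

As far as these compounds go, it remains open whether bromo, an amine or a carboxylic acid in place of chloro would give a number as low as chloro does.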